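The source may hold more compounds than are shown below. What is called first, only, known or untested is meant among the compounds shown, and "the series" means these compounds.

Compound 2 `N[C@H]1CC[C@H](Nc2c(C(=O)NCc3ccccn3)nc(Br)c3cccnc23)CC1` and compound 1 `COc1ccc(CNC(=O)c2nc(Br)c3cccnc3c2N[C@H]2CC[C@H](N)CC2)cc1` share a core and differ only at the group on the amide nitrogen. For compound 1 the entry in a functional assay on MCF7 cells (Homo sapiens) for cytotoxicity, read by MTT assay, with a stated time of 72 h (a lower number here means a stronger inhibitor, a higher number a weaker inhibitor), reads "not determined" (no result reported), whereas compound 2 gives 15000 nM in this assay. Among the measured compounds shown here, that single number is all there is, so compound 2 stands alone as the only measured compound of the set. Compound 3 `N[C@H]1CC[C@H](Nc2c(C(=O)NC3CCCCC3)nc(Br)c3cccnc23)CC1` differs from compound 2 in one place: cyclohexyl in place of (pyridin-2-yl)methyl on an amide-type nitrogen. For the measured compounds named here, no step between two measured compounds is on record, so nothing here shows how such a change shifts the read-out. With no evidence either way, the step of no change at the digits printed from compound 2 to compound 3 (within the scatter) is estimated to be small, within the usual scatter rather than beyond it. Compound 3 is therefore expected to give about 15000 nM in this assay, most likely between 5000 nM and 45000 nM.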

Compound 3, half-maximal inhibitory concentration: 5200 nM
Estimate against measurement, compound 3: 2.9-fold (0.46 log units) above, and the stated range covers the measured number.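

In this assay this position on the amide-type nitrogen responds to what it carries: cyclohexyl in place of (pyridin-2-yl)methyl gives a modest but real shift (a 2.9-fold lower number from compound 2 to compound 3 (0.46 log units; beyond the scatter)). Compound 3 has no aromatic ring and no hydrogen-bond acceptor in this group, yet it gives the lower number, so neither feature is needed to reach that level of cytotoxicity. Nothing on hand explains why the number moves.

This single step changes the ring and the way it is attached together, so it cannot show which of the two matters. Going by these compounds, how a plain phenyl, a smaller cyclopentyl or an open hexyl chain would read at this position remains open, as does whether an amine on the ring would raise or lower the number.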